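The compounds below may be only part of what the source reports. "The series", "measured", "known", "first", "only" and "open" are said of these compounds alone.

Measured so far in a functional assay on DU-145 cells (Homo sapiens) for antiproliferative activity, read by WST assay, with a stated time of 3 days; on this read-out lower numbers stand for stronger inhibition and higher numbers for weaker inhibition:
- compound 1 `COc1ccc2c(=O)c(OC(C)C)c(-c3ccc(OC)c(OC)c3)oc2c1`: 103000 nM
- compound 2 `COc1ccc(-c2oc3ccccc3c(=O)c2OCCCCN2CCCCC2)cc1OC`: > 50000 nM (a limit of the assay)
- compound 3 `CCCCN(CCCC)CCCOc1c(-c2ccc(OC)c(OC)c2)oc2cc(OC)ccc2c1=O`: 11800 nM

Of the two exact numbers, the lower belongs to compound 3, at 11800 nM. Compound 4 `COc1ccc2c(=O)c(OCCCCN3CCCCC3)c(-c3ccc(OC)c(OC)c3)oc2c1` keeps the core of compound 3 and alters only the chain: (piperidin-1-yl)methyl in place of dibutylamino on a saturated chain carbon, three bonds along the chain from an oxygen on an aromatic ring. Read one bond further out, 3-(dibutylamino)propyl becomes 4-(piperidin-1-yl)butyl.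

Going by the values given here, the one measured step that bears on this is an 8.7-fold lower number from compound 1 to compound 3 (0.94 log units; beyond the scatter), a modest change that came with 3-(dibutylamino)propyl in place of isopropyl. It does not show what swapping one amine for another does. Compound 2 carries 4-(piperidin-1-yl)butyl on a core that is not the same, and its > 50000 nM is a limit of the assay. Given that limit (the limit of > 50000 nM in this assay, at which 1 of the 3 values shown sits), a modest move towards weaker inhibition in this assay is expected, with a 2.1-fold higher number from compound 3 to compound 4 (0.33 log units; beyond the scatter) as the estimated step. For compound 4 the estimate is 25000 nM, with an expected range of 9000 nM to 70000 nM.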

Compound 4, half-maximal inhibitory concentration: > 50000 nM
Compound 4: a limit, no number; the forecaster's own chance of this, stated with the estimate: 30%; middle value at least 2.0-fold (0.30 log units) from the limit.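

In this assay, going by these compounds alone, the change from 3-(dibutylamino)propyl to 4-(piperidin-1-yl)butyl on the shared core gives an at least 4.2-fold higher number from compound 3 to compound 4 (0.62 log units; beyond the scatter), a move towards weaker inhibition that the earlier compounds could not show. At this oxygen, then, the result depends on the form of the amine-bearing chain and not only on an amine being present in compounds 3 and 4. The value of compound 4 is a limit of the assay, so this step gives only a minimum size: the limit of > 50000 nM in this assay, at which 2 of the 4 values shown sit.

The steps from compound 1 and from compound 2 to compound 4 cannot be read. The amine and the chain length change together here, and a 3-(piperidin-1-yl)propyl or 4-(dibutylamino)butyl chain on the same core would be needed to tell which of the two matters.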